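Swapping the amide substituent for a methylpiperazine ring

The compounds below may be only part of what the source reports. "The series", "measured", "known", "first", "only" and "open" are said of these compounds alone.

Going by the values given here, compound 2 `Nc1nn(CC(=O)NCc2ccco2)c2nc(-c3ccccc3)cc(C(F)(F)F)c12` gives the lowest of the two numbers so far in a functional assay on HeLa cells (Homo sapiens) for cytotoxicity, read by MTT assay, with a stated time of 24 h (on this read-out lower numbers stand for stronger inhibition and higher numbers for weaker inhibition), at 7100 nM. Its nearest neighbour is compound 1 `CNC(=O)Cn1nc(N)c2c(C(F)(F)F)cc(-c3ccccc3)nc21`, which in this assay gives 12200 nM; the two values sit within the scatter of each other, so no order can be read from them. Compound 3 `CN1CCN(C(=O)Cn2nc(N)c3c(C(F)(F)F)cc(-c4ccccc4)nc32)CC1` differs from compound 2 by 4-methylpiperazin-1-yl in place of ((furan-2-yl)methyl)amino on a carbonyl carbon. Among the compounds with values here, the only measured step that touches this part of the molecule is a 1.7-fold lower number from compound 1 to compound 2 (0.24 log units; within the scatter), which changed the group on the same amide-type nitrogen. Within the data shown here, since that change did not move the number beyond the scatter, and no measured step covers a ring of the kind that enters here, a step of no more than scatter size is expected from compound 2 to compound 3, a 1.3-fold higher number from compound 2 to compound 3 (0.10 log units; within the scatter). Compound 3 is therefore estimated at 9000 nM in this assay, with a range from 3000 nM to 30000 nM.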

Compound 3, half-maximal inhibitory concentration: 17700 nM
Beside the measured number, compound 3's estimate is 2.0-fold (0.29 log units) below it, and the stated range covers the measured number.
By their numbers in this assay, from the lowest: compounds 2, 1 and 3 (each within the scatter of the next, the first and the last beyond it).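

In this assay a change on this carbonyl carbon now gives a step beyond the scatter, which the earlier pair did not: a 2.5-fold higher number from compound 2 to compound 3 (0.40 log units; beyond the scatter) when 4-methylpiperazin-1-yl replaces ((furan-2-yl)methyl)amino, though the step is only modest. The same ring in place of methylamino gives a 1.5-fold higher number from compound 1 to compound 3 (0.16 log units; within the scatter) and so does not separate those two compounds, which means the ring stands apart only from the furan-bearing amide and not from the smaller one. Nothing measured here explains the difference between these groups.

Still open, as far as these compounds go, is whether a piperidine or morpholine ring on this carbonyl carbon would read like 4-methylpiperazin-1-yl, and whether a benzylamino group would read like ((furan-2-yl)methyl)amino. A carboxylic acid in place of the amide also remains an open case.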